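This account rests on a few compounds, and the source may have more. Where it says the series, first, only, none or still open, it means among the compounds named here.

In an in vitro ADME assay on microsomes from liver (Simiiformes) (a lower number here means that the compound disappears faster, a higher number that the compound lasts longer), compound 1 `CCc1cc(CCCOc2c(C)cc(-c3noc(C)n3)cc2C)on1` gives 0.183 h while compound 2 `COCc1cc(CCCOc2c(C)cc(-c3noc(C(F)(F)F)n3)cc2C)on1` gives 1.58 h and compound 3 `Cc1cc(CCCOc2c(C)cc(-c3noc(C(N)=O)n3)cc2C)on1` gives 2.3 h as its half-life. Compound 3 thus lies within the scatter of compound 2 and clearly beyond the scatter above compound 1. Compound 4 `Cc1cc(CCCOc2c(C)cc(-c3noc(C(F)F)n3)cc2C)on1` carries difluoromethyl in place of carbamoyl on an aromatic carbon and has not yet been measured. Among the measured compounds shown here, no measured pair shows this change alone. The closest guide is compound 2, with trifluoromethyl on that carbon and a value of 1.58 h, although it also differs elsewhere. The expected change is small, a step of a 1.9-fold lower number from compound 3 to compound 4 (0.28 log units; within the scatter) that stays within the scatter. For compound 4 the estimated half-life is 1.2 h (expected range 0.4 h to 3 h).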

Compound 4, half-life: 1.42 h
Compound 4: the middle estimate sits 1.2-fold (0.07 log units) below what was measured; the measured number falls inside the stated range.
By their numbers in this assay, from the lowest: compound 1; then compounds 4, 2 and 3 (each within the scatter of the next).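

Among the compounds shown here, the step of a 1.6-fold lower number from compound 3 to compound 4 (0.21 log units; within the scatter) is the first direct comparison at this position, and it shows that in this assay the half-life does not separate carbamoyl from difluoromethyl on this aromatic carbon. Losing the hydrogen-bond donor of carbamoyl thus brings no change beyond the scatter here. For the compounds shown here, nothing measured so far offers an explanation for this result. Going by these compounds, whether a carboxylic acid, a nitrile or an amine on this carbon would read the same remains open. So does whether difluoromethyl would behave alike on the core of compound 1.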